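The source may hold more compounds than are shown below. What is called first, only, known or untested is meant among the compounds shown, and "the series" means these compounds.

Measured so far in an assay on isolated protein for inhibition of Maltase-glucoamylase (Homo sapiens), with a stated time of 15 min; on this read-out lower numbers stand for stronger inhibition and higher numbers for weaker inhibition: compound 1 `O=C(N/N=C\c1ccccn1)c1ccc(-c2nc3ccccc3s2)cc1` gives 10200 nM; compound 2 `COc1ccc(/C=N/NC(=O)c2ccc(-c3nc4ccccc4s3)cc2)c(O)c1` gives 6970 nM; compound 3 `O=C(N/N=C/c1ccc(O)cc1O)c1ccc(-c2nc3ccccc3s2)cc1` gives 5580 nM.

Compound 2 stands second highest of these three numbers. Its nearest neighbour is compound 3, and the step of a 1.2-fold lower number from compound 2 to compound 3 (0.10 log units; within the scatter) shows the two lie within the scatter; the gap to compound 1 is likewise within the scatter, so no order among the three can be claimed.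

Compound 4 `O=C(N/N=C/c1ccc(F)c(Br)c1)c1ccc(-c2nc3ccccc3s2)cc1` differs from compound 2 in one place: 3-bromo-4-fluorophenyl in place of 2-hydroxy-4-methoxyphenyl on a carbon with a double bond to nitrogen. Going by the values given here, the only measured step on the aromatic ring attached to the carbon with a double bond to nitrogen is a 1.2-fold lower number from compound 2 to compound 3 (0.10 log units; within the scatter), and it stayed within the scatter; compound 1, which carries a different ring at the same place, also sits within the scatter of compound 2. The three numbers therefore give no sign that this ring moves this assay much, and the step of a 1.3-fold higher number from compound 2 to compound 4 (0.11 log units; within the scatter) is expected to stay within the scatter. Compound 4 is estimated at 9000 nM, with a range from 4000 nM to 25000 nM.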

Compound 4, half-maximal inhibitory concentration: 28000 nM
Compound 4: middle estimate off by 3.1-fold (0.49 log units), on the low side; measured number above the stated range.
By their numbers in this assay, from the lowest: compounds 3, 2 and 1 (each within the scatter of the next); then compound 4.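

In this assay, the aromatic ring on the carbon with a double bond to nitrogen proves able to shift the read-out. Placing 3-bromo-4-fluorophenyl here gives a 4.0-fold higher number from compound 2 to compound 4 (0.60 log units; beyond the scatter) and a 5.0-fold higher number from compound 3 to compound 4 (0.70 log units; beyond the scatter), both beyond the scatter, whereas the earlier step at this place, a 1.2-fold lower number from compound 2 to compound 3 (0.10 log units; within the scatter), stayed within it. The entering ring has 0 hydrogen-bond donors and 0 hydrogen-bond acceptors, while the 2-hydroxy-4-methoxyphenyl it replaces has both, but the data shown offer no measured explanation for the weaker inhibition.

Because the halogens enter as the oxygen substituents leave, the compounds shown cannot separate the contribution of either change. On these data alone, how an amine or a carboxylic acid on this ring would read out also remains open.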